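This account rests on a few compounds, and the source may have more. Where it says the series, first, only, none or still open, it means among the compounds named here.

Compound 1 `COc1ccc(/C=C/c2cc(OC)c(OC)c(OC)c2-c2ccc(F)c(F)c2)cc1` gives 6900 nM
Compound 2 `COc1ccc(/C=C/c2cc(OC)c(OC)c(OC)c2-c2ccccc2)cc1` gives 11000 nM
Compound 3 `COc1ccc(/C=C/c2cc(OC)c(OC)c(OC)c2-c2ccc3ccccc3c2)cc1` gives 16000 nM

All three values come from a functional assay on SK-N-SH cells (Homo sapiens) for cytotoxicity, read by MTT assay, with a stated time of 48 h; a higher number here means a weaker inhibitor, a lower number a stronger inhibitor. Compound 3, at 16000 nM, has one close neighbour and one further off: the measured steps to it are a 1.5-fold higher number from compound 2 to compound 3 (0.16 log units; within the scatter) and a 2.3-fold higher number from compound 1 to compound 3 (0.37 log units; beyond the scatter).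

Compound 4 `COc1ccc(/C=C/c2cc(OC)c(OC)c(OC)c2-c2ccc(F)c(C)c2)cc1` has 4-fluoro-3-methylphenyl in place of the naphthalen-2-yl of compound 3 on an aromatic carbon: 4-fluoro-3-methylphenyl in place of naphthalen-2-yl on an aromatic carbon. The new group is a single substituted phenyl, as is the 3,4-difluorophenyl of compound 1, so the closest guide is the reverse of a 2.3-fold higher number from compound 1 to compound 3 (0.37 log units; beyond the scatter). The plain phenyl of compound 2 gives a smaller reverse guide, a 1.5-fold higher number from compound 2 to compound 3 (0.16 log units; within the scatter). A modest move to a lower number in this assay is therefore expected, possibly none beyond the scatter. The expected step is a 1.9-fold lower number from compound 3 to compound 4 (0.27 log units; within the scatter). For compound 4 the estimated value is 8500 nM, with an expected range from 4500 nM to 16000 nM.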

Compound 4, half-maximal inhibitory concentration: 19000 nM
For compound 4 the middle estimate is 2.2-fold (0.35 log units) below the measured one; measured number outside the range, above it.
By their numbers in this assay, from the lowest: compounds 1, 2, 3 and 4 (each within the scatter of the next, the first and the last beyond it).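

In this assay, a substituted phenyl at this position does not by itself lower the number: replacing naphthalen-2-yl with 4-fluoro-3-methylphenyl gives a step within the scatter (a 1.2-fold higher number from compound 3 to compound 4 (0.07 log units; within the scatter)), and so does adding the two substituents to the plain phenyl (a 1.7-fold higher number from compound 2 to compound 4 (0.24 log units; within the scatter)). The exchange of a single substituent, methyl in place of fluoro, gives a step beyond the scatter (a 2.8-fold higher number from compound 1 to compound 4 (0.44 log units; beyond the scatter)), so the choice of substituent on this phenyl can matter as much as any ring change shown here. Nothing measured here explains this difference.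

The compounds shown leave open how an amine or a carboxylic acid on this phenyl would read in this assay. They also leave open whether a pyridinyl group could take the place of the phenyl.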